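3-fluorophenyl in place of 4-aminophenyl: compound 4 pending

The source may hold more compounds than are shown below. What is called first, only, known or untested is meant among the compounds shown, and "the series" means these compounds.

Measured so far in an ADME assay on cells (spleen, Mus musculus, strain C57BL/6) for inhibition, read by flow cytometry and propidium iodide staining, with a stated time of 24 h, at 37 degrees C; a lower number here means that less compound is needed, a higher number that more compound is needed for the effect
- compound 1 `O=C(O)CCc1cn(CC(=O)NCc2ccccc2)nn1` gives 1420 uM
- compound 2 `Nc1cccc(-c2cn(CC(=O)NCc3ccccc3)nn2)c1` gives 800 uM
- compound 3 `Nc1ccc(-c2cn(CC(=O)NCc3ccccc3)nn2)cc1` gives 1240 uM

Compound 3 (1240 uM) stands within the scatter of both other compounds, with a 1.1-fold lower number from compound 1 to compound 3 (0.06 log units; within the scatter) and a 1.6-fold higher number from compound 2 to compound 3 (0.19 log units; within the scatter) as its steps. The next structure, compound 4 `O=C(Cn1cc(-c2cccc(F)c2)nn1)NCc1ccccc1`, carries 3-fluorophenyl in place of 4-aminophenyl on an aromatic carbon. Among the measured compounds shown here, no measured compound holds this group, so the evidence is indirect. The closest step is the exchange of one aminophenyl for the other, a 1.6-fold higher number from compound 2 to compound 3 (0.19 log units; within the scatter). The replacements of 2-carboxyethyl, a 1.8-fold lower number from compound 1 to compound 2 (0.25 log units; within the scatter) and a 1.1-fold lower number from compound 1 to compound 3 (0.06 log units; within the scatter), also stayed within the scatter. None of the three steps gives a direction for this assay, so no shift beyond the scatter is expected. The expected size is a 1.4-fold lower number from compound 3 to compound 4 (0.14 log units; within the scatter), which is no more than a working estimate. For compound 4 the estimated value is 900 uM, with an expected range from 420 uM to 1800 uM.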

Compound 4, concentration for half-maximal effect: "non-toxic" (no number reported)
The entry for compound 4 holds no number, and the estimate cannot be compared.
By their numbers in this assay, from the lowest: compounds 2, 3 and 1 (each within the scatter of the next).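

Among the compounds shown here, compound 4 is entered as "non-toxic" in this assay without a number, so no step from compound 3 to compound 4 can be read. The compounds shown leave open how 3-fluorophenyl compares in number with the aminophenyl groups on the shared core. Nothing available explains this entry.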